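The source may hold more compounds than are shown below. What is called first, only, known or untested is meant among the compounds shown, and "the series" means these compounds.

Measured compounds:
Compound 1 `CC(C)Cc1csc(N)c1C(=O)c1ccc(Cl)cc1`: 1%
Compound 2 `CC(C)(C)Cc1csc(N)c1C(=O)c1ccc(Cl)cc1`: 1%

In an assay on CHO cells for displacement of a labelled ligand from adenosine receptor A1 (Homo sapiens), read by scintillation counting, tested at 10 uM (a higher number here means more inhibition at the concentration tested (going by the name of the read-out), a lower number less inhibition), compound 1 gives 1%, and compound 2 gives 1%. Going by the values given here, the one measured step, no change at the digits printed from compound 1 to compound 2 (within the scatter), places methyl in place of hydrogen on a saturated chain carbon bound to three saturated chain carbons. Compound 2 therefore stands level with compound 1 at the digits shown, with no change beyond the scatter between them.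

Compound 3 `CC(C)(C)Cc1c(-c2ccncc2)sc(N)c1C(=O)c1ccc(Cl)cc1` differs from compound 2 by pyridin-4-yl in place of hydrogen on an aromatic carbon. Among the compounds with values here, the only measured step concerns a saturated chain carbon, far in kind from the addition of pyridin-4-yl on an aromatic carbon, and its size was nil; no measured step adds an aromatic ring to the shared core. Nothing measured therefore supports more than a small shift, and the step of a number 7 percentage points higher from compound 2 to compound 3 (within the scatter) is expected to be modest at most. Compound 3 is estimated at 8%, within a range of 0% to 35%.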

Compound 3, a percentage reported as inhibition, at one concentration (the size of the read-out at that concentration, not a potency): 1%
The estimate for compound 3 lay 7 percentage points above the measured number; the measured number falls inside the stated range.
By their numbers in this assay, from the lowest: compounds 1, 2 and 3 (each within the scatter of the next).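

In this assay, pyridin-4-yl in place of hydrogen on the aromatic carbon next to the ring sulfur gives no change at the digits printed from compound 2 to compound 3 (within the scatter). Going by these compounds alone, compound 1 and compound 2 differ only in the saturated chain, so this is the first evidence on the ring position itself: adding a six-membered aromatic ring there leaves compound 3 at 1%, as flat a result as the chain change gave. Nothing available accounts for this flat result.

As far as these compounds go, what a smaller or differently built group on this aromatic carbon, such as an amine, a carboxylic acid or a longer chain, would do remains open. Also open, from the compounds shown here alone, is whether pyridin-4-yl would give the same result if the neopentyl group or the amino group were replaced.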